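The source may report more compounds than this note shows. Statements on the series, on what has been measured and on what is new or still open speak of the compounds shown alone.

Measured so far in a functional assay on the whole organism (strain NMRI) with Mus musculus as the target, with a stated time of 60 min, at a dose of 10 mg/kg by the intraperitoneal route; a higher number here means a stronger effect of the compound at the dose given, a lower number a weaker effect:
compound 1 `CCCSc1nnc(Cc2ccccc2Oc2ccccc2)[nH]1`, 139%
compound 2 `CSc1nnc(Cc2ccc(Cl)cc2Oc2ccccc2Cl)[nH]1`, 132%
compound 3 `Fc1ccccc1Oc1cc(Cl)ccc1Cc1nnc(SCc2ccccc2)[nH]1`, 169%

Among these three numbers compound 1 stands second highest. Compound 2 is its nearest neighbour and sits within the usual scatter of it, so the two cannot be told apart. Compound 3 lies furthest from compound 1, higher by a margin beyond the scatter. Compound 4 `CCOc1nnc(Cc2ccccc2Oc2ccccc2)[nH]1` differs from compound 1 in one place: ethoxy in place of propylsulfanyl on an aromatic carbon. Among the measured compounds shown here, no pair of measured compounds shows this change, so nothing here tells how it bears on this assay. The account therefore expects the step of a number 11 percentage points lower from compound 1 to compound 4 (beyond the scatter) to be small and to stay within the scatter. For compound 4 the estimate in this assay is 128%, expected to fall between 95% and 162%.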

Compound 4, a percentage reported as activity, at one dose (the size of the read-out at that dose, not a potency): 126%
The estimate for compound 4 lay 2 percentage points above the measured number; low and high end bracket the measured number.
By their numbers in this assay, from the lowest: compounds 4, 2 and 1 (each within the scatter of the next, the first and the last beyond it); then compound 3.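

In this assay, among the compounds shown here, ethoxy in place of propylsulfanyl on this aromatic carbon gives a number 13 percentage points lower from compound 1 to compound 4 (beyond the scatter), the first reading of a change at this position, and the step is modest. With ethoxy at this position, compound 4 still gives 126%. Nothing measured here accounts for the step.

The step changes the linking atom and the chain length together, so the compounds shown do not separate the two. Ethylsulfanyl or propoxy on this carbon would tell them apart, while an amine there remains an open question.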